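From hydroxymethyl to carbamoyl: one swap on compound 1

A few compounds are considered here, and "the series" means these few. Any claim that something is new, unique, unknown or untested is made for them only; others in the source may bear on it.

Compound 1 `Cc1cc(CCC#N)cc(C)c1Oc1cc(Nc2ccc(C#N)cc2)c(N)cc1CO` gives 3.68
Compound 2 `COC(=O)c1cc(N)c(Nc2ccc(C#N)cc2)cc1Oc1c(C)cc(/C=C/C#N)cc1C` gives 4.15

Among the compounds with values here, these two values come from a physicochemical assay for lipophilicity, at pH 7.4 (on this read-out higher numbers stand for higher lipophilicity and lower numbers for lower lipophilicity), and are the only measurements so far. Compound 1 holds the lower of the two numbers. Compound 2, at 4.15, stands higher by a gap beyond the usual scatter of repeated measurements. The two compounds differ in more than one place, so this gap cannot be tied to any single group.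

The next compound, compound 3 `Cc1cc(CCC#N)cc(C)c1Oc1cc(Nc2ccc(C#N)cc2)c(N)cc1C(N)=O`, keeps the core of compound 1 and carries carbamoyl in place of hydroxymethyl on an aromatic carbon. Within the data shown here, no pair of measured compounds shows this exchange on its own, so the data offer no direct guide to its size. The expectation therefore rests only on the structural change and is a cautious one. A slight fall in this assay is expected, probably within the scatter (a number 0.18 log units lower from compound 1 to compound 3 (within the scatter)). Compound 3 is expected at 3.5, in an estimated range from 3.1 to 3.9 on this read-out.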

Compound 3, partition coefficient: 2.65
For compound 3 the middle estimate is 0.85 log units above the measured one; measured number outside the range, below it.
By their numbers in this assay, from the lowest: compound 3; then compound 1; then compound 2.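

Within the data shown here, for the first time a single change can be read on its own: in this assay, placing carbamoyl instead of hydroxymethyl on the aromatic carbon para to a (4-cyanophenyl)amino group gives a number 1.03 log units lower from compound 1 to compound 3 (beyond the scatter), a large step for an exchange of one small group on an otherwise unchanged molecule. The two groups have the same counts of hydrogen-bond donors and acceptors and neither carries a net charge, so these counts do not tell them apart, even though the read-out clearly does. No other measurement shown here bears on why this step is so large.

Among these compounds, this remains the only pair showing this exchange, so it is open whether carbamoyl in place of hydroxymethyl would move the number as far if the rest of the molecule were different. Going by these compounds, it is also open where groups such as a carboxylic acid or an aminomethyl group would fall on this read-out if placed on the same aromatic carbon of the core of compound 1.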